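Thioether Variant Within a Series at the Half-Life Limit

This account rests on a few compounds, and the source may have more. Where it says the series, first, only, none or still open, it means among the compounds named here.

Compound 1, `COc1ccc(CCOc2ccc(-c3c(C)nc(C)c([C@H](OC(C)(C)C)C(=O)O)c3N3CCC(C)(C)CC3)cc2)cc1`: in an ADME assay on microsomes from liver (Rattus norvegicus) for metabolic stability, read by LC-MS, tested at 0.5 uM (on this read-out higher numbers stand for a longer-lived compound and lower numbers for a shorter-lived compound), compound 1 gives > 2 h, which is a limit of the assay.
Compound 2, `Cc1cc(CCOc2ccc(-c3c(C)nc(C)c([C@H](OC(C)(C)C)C(=O)O)c3N3CCC(C)(C)CC3)cc2)ccc1F`: in this assay compound 2 gives > 2 h, also a limit.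
Compound 3, `Cc1nc(C)c([C@H](OC(C)(C)C)C(=O)O)c(N2CCC(C)(C)CC2)c1-c1ccc(OCCc2cc(F)c(F)cc2F)cc1`: in this assay compound 3 gives > 2 h, again a limit.

Compound 3 therefore stands at the limit shared by every measured value here (the limit of > 2 h in this assay, at which 3 of the 3 values shown sit). Compound 4 is `Cc1nc(C)c([C@H](OC(C)(C)C)C(=O)O)c(N2CCC(C)(C)CC2)c1-c1ccc(SCCc2ccc(F)cc2)cc1`; it differs from compound 3 by (2-(4-fluorophenyl)ethyl)sulfanyl in place of 2-(2,4,5-trifluorophenyl)ethoxy on an aromatic carbon. The measured steps at this position are a step that the two limits leave unreadable from compound 1 to compound 3 and a step that the two limits leave unreadable from compound 2 to compound 3, and likewise a step that the two limits leave unreadable from compound 1 to compound 2; none gives a readable size or direction. The data offer no basis for expecting a step beyond the scatter, so the step that the limit leaves unreadable from compound 3 to compound 4 is estimated to be small. Compound 4 is expected to give about 2.5 h, in the range 1 h to 6 h, most likely again reported as a limit.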

Compound 4, half-life: > 2 h
Compound 4: only a limit was reported (the forecaster's own chance of this, stated with the estimate: 70%); the middle value does not contradict the limit.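

No step from compound 1, compound 2 or compound 3 to compound 4 can be read, because all four sit at one limit: the limit of > 2 h in this assay, at which 4 of the 4 values shown sit.

The compounds shown leave open how long each actually lasts in this assay, and whether the (2-(4-fluorophenyl)ethyl)sulfanyl group changes that at all.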